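The compounds below may be only part of what the source reports. "The series", "measured", "known", "first", "only" and "open" are said of these compounds alone.

Of the compounds shown here, two have been measured. Compound 1 `N/C(=N\NC(=S)N1CCN(c2ccccn2)CC1)c1ccc(F)cn1` in a functional assay on A-431 cells (Homo sapiens) for cytotoxicity, read by MTT assay, with a stated time of 72 h, tested at 100 uM (on this read-out lower numbers stand for less inhibition of growth and higher numbers for more inhibition of growth at the one concentration tested), gives 77.1%. Compound 2 `Cc1ccnc(/C(N)=N/NC(=S)N2CCOCC2)c1` in this assay gives 82.8%. The two numbers lie within the usual scatter of each other, so compound 1 cannot be set apart from compound 2 on this read-out; both show marked inhibition of growth at the single concentration tested. Among the measured compounds shown here, no pair of measured compounds differs in one place only, so no measured step exists against which a single structural change could be calibrated.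

Compound 3 `N/C(=N\NC(=S)N1CCN(c2ccccn2)CC1)c1ccccn1` is the untested relative of compound 1. The change is hydrogen in place of fluoro on an aromatic carbon. Fluoro leaves and hydrogen enters on an aromatic carbon, with the rest of compound 1 untouched. For the measured compounds named here, with no measured step to lean on, the expectation is a number 5.1 percentage points lower from compound 1 to compound 3 (within the scatter), a step that should stay within the scatter, with only a slight tendency toward less inhibition of growth. Compound 3 is accordingly estimated at 72%, with a range from 55% to 86%.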

Compound 3, percent growth inhibition at one concentration: 91.9%
Beside the measured number, compound 3's estimate is 19.9 percentage points below it; measured number outside the range, above it.
By their numbers in this assay, from the lowest: compounds 1, 2 and 3 (each within the scatter of the next, the first and the last beyond it).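

In this assay, among the compounds shown here, the step from 5-fluoropyridin-2-yl to pyridin-2-yl is the first that isolates one place, and it gives a number 14.8 percentage points higher from compound 1 to compound 3 (beyond the scatter). At this aromatic carbon, two atoms from the ring nitrogen and para to a large group, the fluoro therefore does not leave the read-out unchanged: its replacement by hydrogen goes with more inhibition of growth, at least in this single pair and at the one concentration tested. No measured evidence accounts for the size or direction of this step.

From the compounds shown here alone, it remains open whether a chloro, a methyl or a methoxy at this carbon would read like compound 1 or like compound 3, and so whether the step is particular to fluoro or extends to other groups here. Going by these compounds, it is also open whether the same replacement would give a comparable step on a different core, such as that of compound 2, which differs from compound 1 and compound 3 in more than one place.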